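This account rests on a few compounds, and the source may have more. Where it says the series, first, only, none or still open, it means among the compounds named here.

Working notes on the series. Compound 1 `COc1ccc(-c2cccc(C(=O)N(C)C)c2)cc1S(=O)(=O)Nc1ccc2ccc(N(C)C(=O)c3ccccc3)cc2c1` carries a methyl on the amide nitrogen toward the benzamide end; in a functional assay on CHO cells for agonist activity at Orexin/Hypocretin receptor type 1 (Homo sapiens) (a higher number here means a larger maximal response, a lower number a smaller maximal response), compound 1 gives "nd" (no result reported), so no number is available there. Going by the values given here, compound 2 `COc1cccc(C(=O)Nc2cccc3ccc(NS(=O)(=O)c4cc(-c5cccc(C(=O)N(C)C)c5)ccc4OC)cc23)c1` has the only number in the set: in this assay compound 2 gives 107%, a full response against the reference. Compound 3 `COc1cccc(C(=O)N(C)c2cccc3ccc(NS(=O)(=O)c4cc(-c5cccc(C(=O)N(C)C)c5)ccc4OC)cc23)c1` differs from compound 2 only by methyl in place of hydrogen on an amide-type nitrogen. Among the compounds with values here, no measured pair shows this change, so the size of the step is open; a moderate decrease beyond the scatter seems more likely than an increase. For compound 3 the estimated step is a number 22 percentage points lower from compound 2 to compound 3 (beyond the scatter). Compound 3 is therefore expected to give 85%, within 35% to 115%.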

Compound 3, largest response reached (Emax), in percent of the reference or control that the assay uses: 101%
Beside the measured number, compound 3's estimate is 16 percentage points below it, within the range that was stated.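

In this assay the step is a number 6 percentage points lower from compound 2 to compound 3 (within the scatter), so the two compounds cannot be told apart by their maximal response. Going by these compounds alone, this is the first measured reading of methyl in place of hydrogen on this amide-type nitrogen, and it shows that in this pair a full response does not depend on the amide hydrogen.

What the compounds shown leave open is whether an ethyl group, a longer chain or a chain ending in an amine on the same nitrogen would keep that response. Nothing at hand bears on the cause of this result.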